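Phenoxy for propyl on the aryl ring: compound 4

The source may hold more compounds than are shown below. What is called first, only, known or untested is meant among the compounds shown, and "the series" means these compounds.

Measured compounds in a functional assay on brain (Rattus norvegicus, strain Wistar) for inhibition; a lower number here means a stronger inhibitor, a higher number a weaker inhibitor:
compound 1 `CCCCc1ccc(-c2c(C)[nH]c(=O)n2CCCC)cc1` gives 12000 nM
compound 2 `CCCCc1ccc(-c2c(C)[nH]c(=O)n2-c2ccccc2)cc1` gives 16600 nM
compound 3 `CCCc1ccc(-c2c(C)[nH]c(=O)n2C)cc1` gives 21500 nM

The three values lie close together. Compound 3 sits within the scatter of both other compounds: against compound 2 and against compound 1 the gaps are small, so the three numbers are read as one level rather than as an order. Among the measured compounds shown here, the one step between compounds that differ in a single place, a 1.4-fold higher number from compound 1 to compound 2 (0.14 log units; within the scatter), shows that exchanging an alkyl chain for an aromatic ring on the core nitrogen left this assay unchanged within the scatter.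

Compound 4 `Cc1[nH]c(=O)n(C)c1-c1ccc(Oc2ccccc2)cc1` is not yet measured. It differs from compound 3 by phenoxy in place of propyl on an aromatic carbon. For the measured compounds named here, no measured pair carries this exact exchange on the aromatic carbon, so the only guide is the step from compound 1 to compound 2, where an alkyl-to-aryl swap at another place moved nothing beyond the scatter. On that basis no step beyond the scatter is expected for compound 4, so a 1.2-fold lower number from compound 3 to compound 4 (0.08 log units; within the scatter) is estimated as flat. Compound 4 is expected at 18000 nM, with a range from 6000 nM to 60000 nM.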

Compound 4, half-maximal inhibitory concentration: 8100 nM
Beside the measured number, compound 4's estimate is 2.2-fold (0.35 log units) above it; the range from low to high includes it.
By their numbers in this assay, from the lowest: compounds 4, 1, 2 and 3 (each within the scatter of the next, the first and the last beyond it).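

In this assay, the aromatic carbon that carries propyl or phenoxy is the only place among the compounds shown where a single exchange moves the number beyond the scatter: phenoxy in place of propyl gives a 2.7-fold lower number from compound 3 to compound 4 (0.42 log units; beyond the scatter). Among the compounds shown here, the step is modest, but the only earlier single-place exchange, at the core nitrogen, gave a 1.4-fold higher number from compound 1 to compound 2 (0.14 log units; within the scatter) and stayed within the scatter, so this aromatic carbon responds to a change where that nitrogen, in its one pair, did not. The exchange brings in both an oxygen and a six-membered aromatic ring of carbon only, the compounds shown do not separate the two, and no evidence at hand accounts for the step.

Open, from the compounds shown here alone, is whether a benzyloxy group or a longer chain such as hexyl at this aromatic carbon would hold, extend or lose the step, and whether an amine or a carboxylic acid on the phenoxy ring would be tolerated. Also open, going by these compounds, is whether phenoxy gives a similar step when butyl or phenyl, rather than methyl, sits on the core nitrogen.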